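The compounds below may be only part of what the source reports. "The series", "measured", "known", "first", "only" and "open" are said of these compounds alone.

In a functional assay on SW-620 cells (Homo sapiens) for cytotoxicity, read by MTT assay, with stated times of 4 h and 72 h, tested at 2 uM (a higher number here means a weaker inhibitor, a lower number a stronger inhibitor), compound 1 `Cc1cc(Nc2ccc(C(=O)/C=C/c3ccc(OC(F)(F)F)cc3)cc2)n2nc(SCc3nc4ccccc4[nH]3)nc2n1` gives 220 nM and compound 2 `Cc1cc(Nc2ccc(C(=O)/C=C/c3ccccc3F)cc2)n2nc(SCc3nc4ccccc4[nH]3)nc2n1` gives 250 nM as its value. Only these two numbers are known so far, and compound 2 stands level with compound 1 within the scatter. Compound 3 `Cc1cc(Nc2ccc(C(=O)/C=C/c3ccc(-n4cccn4)cc3)cc2)n2nc(SCc3nc4ccccc4[nH]3)nc2n1` differs from compound 2 by 4-(1H-pyrazol-1-yl)phenyl in place of 2-fluorophenyl on a double-bonded chain carbon bound to a double-bonded chain carbon and keeps the shared core. For the measured compounds named here, the only measured step bearing on this swaps groups at that same place. With a 1.1-fold higher number from compound 1 to compound 2 (0.06 log units; within the scatter) as its size, no step beyond the scatter is expected in this assay here. Going by the values given here, that guide is thin, for no measured compound carries the 4-(1H-pyrazol-1-yl)phenyl group, and so the range is kept wide. The estimated change is a 1.1-fold higher number from compound 2 to compound 3 (0.03 log units; within the scatter) and would leave the two compounds close. For compound 3 the expected value is 270 nM with 110 nM to 650 nM as the estimated range.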

Compound 3, half-maximal inhibitory concentration: 340 nM
The estimate for compound 3 lay 1.3-fold (0.10 log units) below the measured number; the measured number falls inside the stated range.
By their numbers in this assay, from the lowest: compounds 1, 2 and 3 (each within the scatter of the next).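

In this assay, 4-(1H-pyrazol-1-yl)phenyl brings one five-membered aromatic ring with 2 hetero atoms to the place on a double-bonded chain carbon bound to a double-bonded chain carbon, and the result is a 1.4-fold higher number from compound 2 to compound 3 (0.13 log units; within the scatter) for this exchange with 2-fluorophenyl. Comparing 1H-pyrazol-1-yl with trifluoromethoxy on an aromatic carbon gives a 1.5-fold higher number from compound 1 to compound 3 (0.19 log units; within the scatter) and so also stays within the scatter, which leaves the three aromatic groups shown at this place level with one another. Nothing available explains this lack of separation.

Going by these compounds, whether any group at this place can move the number beyond the scatter remains open. A 4-carboxyphenyl group, a 4-(aminomethyl)phenyl group or a saturated ring such as cyclohexyl could test this, as the compounds shown carry an aromatic ring here in every case.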